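Ortho substituent on the urea aryl ring: chloro to hydrogen

The source may hold more compounds than are shown below. What is called first, only, known or untested is meant among the compounds shown, and "the series" means these compounds.

Among the compounds with values here, compound 2 `O=C(Nc1ccccc1Cl)N[C@H]1CC[C@H](Oc2ccc(F)cc2)CC1` is the only member of the series with a numerical result in a functional assay on CRL2813 cells (Homo sapiens) for cytotoxicity, read by sulforhodamine B assay, with a stated time of 5 days (on this read-out lower numbers stand for stronger inhibition and higher numbers for weaker inhibition), where compound 2 gives 9100 nM. Compound 1 `Cc1ccccc1NC(=O)N[C@H]1CC[C@H](Oc2ccc(F)cc2)CC1` returns only a limit of the assay: in this assay compound 1 gives > 20000 nM, which is a limit and not a number (the limit of > 20000 nM in this assay, at which 1 of the 2 values shown sits). Within the data shown here, the single measured step, an at least 2.1-fold lower number from compound 1 to compound 2 (0.34 log units; beyond the scatter), is the only guide for the next change. Compound 3 `O=C(Nc1ccccc1)N[C@H]1CC[C@H](Oc2ccc(F)cc2)CC1` differs from compound 2 by hydrogen in place of chloro on an aromatic carbon. Whether the improvement from methyl to chloro came from chloro arriving or from methyl leaving cannot be separated on two compounds, and hydrogen at this position is new to the series. Compound 3 is expected to give up part of the activity seen for the chloro analogue, with an estimated step of a 1.6-fold higher number from compound 2 to compound 3 (0.22 log units; within the scatter) in this assay. The estimate for compound 3 is 15000 nM, with a range of 6000 nM to 40000 nM, and a fair chance that only a limit is reported.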

Compound 3, half-maximal inhibitory concentration: 20000 nM
Compound 3: middle estimate off by 1.3-fold (0.12 log units), on the low side, and the stated range covers the measured number.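

Hydrogen in place of chloro gives a 2.2-fold higher number from compound 2 to compound 3 (0.34 log units; beyond the scatter) in this assay. Chloro itself therefore counts at this position. Compound 3 carries neither chloro nor methyl, and its number is still higher than that of compound 2. Compound 1 gives a limit and not a number. Hydrogen in place of methyl gives a number no higher from compound 1 to compound 3 (the limit leaves the size open), so the size of this step cannot be read, and methyl and hydrogen stay unranked: the limit of > 20000 nM in this assay, at which 1 of the 3 values shown sits.

Whether the gain is particular to chloro stays open, since fluoro, bromo, methoxy and trifluoromethyl on this carbon are not among the compounds shown. Also open, as far as these compounds go, is whether chloro keeps its effect on another carbon of the ring, and whether a second chloro adds to it.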